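Methyl for trifluoromethyl on the pyridyl ether series

This account rests on a few compounds, and the source may have more. Where it says the series, first, only, none or still open, it means among the compounds named here.

Three compounds carry the same azetidinylmethoxy core and differ only in the group on the pyridine ring. In an assay on brain for binding affinity to Neuronal acetylcholine receptor; alpha4/beta2 (Rattus norvegicus), read by radioligand binding (a lower number here means a stronger inhibitor, a higher number a weaker inhibitor), compound 1 `C=Cc1ccc(OC[C@@H]2CCN2)cn1` gives 1.25 nM; compound 2 `Fc1cncc(OC[C@@H]2CCN2)c1` gives 0.076 nM; compound 3 `FC(F)(F)c1cncc(OC[C@@H]2CCN2)c1` gives 0.49 nM. Compound 3 thus holds the second highest number of the three, beyond the scatter from both neighbours, with compound 2 the lowest.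

The next step goes from compound 3 to compound 4 `Cc1cncc(OC[C@@H]2CCN2)c1`: methyl in place of trifluoromethyl on an aromatic carbon. For the measured compounds named here, the one step that bears on this position is a 6.4-fold higher number from compound 2 to compound 3 (0.81 log units; beyond the scatter), showing that the small fluoro substituent gives a markedly lower number than trifluoromethyl. Methyl is closer in size to fluoro than to trifluoromethyl, so a drop toward the value of compound 2 is expected, though not necessarily all the way; a moderate step down, a 2.5-fold lower number from compound 3 to compound 4 (0.39 log units; beyond the scatter), is the working expectation in this assay. Compound 4 is therefore estimated at 0.2 nM, within a range of 0.06 nM to 0.7 nM.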

Compound 4, inhibition constant: 0.047 nM
Compound 4: the middle estimate sits 4.3-fold (0.63 log units) above what was measured, and the stated range ends above it.
By their numbers in this assay, from the lowest: compounds 4 and 2 (each within the scatter of the next); then compound 3; then compound 1.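

At this position, methyl in place of trifluoromethyl gives a 10-fold lower number from compound 3 to compound 4 (1.02 log units; beyond the scatter) in this assay, so the change of group alone moves the number by a large step. Methyl in place of fluoro gives a 1.6-fold lower number from compound 2 to compound 4 (0.21 log units; within the scatter), so these two groups are not separated here, and of the three groups seen at this place only trifluoromethyl stands apart from the other two. Nothing at hand explains why trifluoromethyl stands apart.

As far as these compounds go, it remains open whether other groups at this place, such as chloro, an amine or a longer chain like ethyl, would stay level with methyl and fluoro or move toward trifluoromethyl. Compound 1 differs from the others in more than one place, so it gives no direct reading on this position.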